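Swapping chloro for trifluoromethyl on the benzyl group

The compounds below may be only part of what the source reports. "The series", "measured", "known", "first", "only" and "open" are said of these compounds alone.

Three sulfonamides share a core and differ only in the aryl group carried on the saturated chain carbon bound to the amine nitrogen. In a functional assay on BE(2)-C cells (Homo sapiens) for inhibition, read by MTT assay, with a stated time of 72 h (a lower number here means a stronger inhibitor of growth, a higher number a weaker inhibitor of growth), compound 1 `O=S(=O)(NCCCNCc1cccc2ccccc12)c1cc(C(F)(F)F)cc(C(F)(F)F)c1` gives 2700 nM, compound 2 `O=S(=O)(NCCCNCc1ccc(Cl)cc1)c1cc(C(F)(F)F)cc(C(F)(F)F)c1` gives 2900 nM, and compound 3 `COc1ccc(CNCCCNS(=O)(=O)c2cc(C(F)(F)F)cc(C(F)(F)F)c2)cc1OC` gives 3600 nM. Compound 2 thus holds the second highest of the three numbers, nearest to compound 1 and furthest from compound 3, with every gap within the scatter: a 1.1-fold higher number from compound 1 to compound 2 (0.03 log units; within the scatter), a 1.3-fold higher number from compound 1 to compound 3 (0.12 log units; within the scatter), a 1.2-fold higher number from compound 2 to compound 3 (0.09 log units; within the scatter).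

Compound 4 `O=S(=O)(NCCCNCc1ccc(C(F)(F)F)cc1)c1cc(C(F)(F)F)cc(C(F)(F)F)c1` is not yet measured. It differs from compound 2 as follows: trifluoromethyl in place of chloro on an aromatic carbon. Within the data shown here, no measured step exchanges chloro for trifluoromethyl, so the nearest guide is the observation that three quite different aryl groups at this position left the numbers within the scatter of one another. A step of similar size, in no particular direction, is therefore expected from compound 2 to compound 4, namely no change at the digits printed from compound 2 to compound 4 (within the scatter). Compound 4 is estimated at 2900 nM, within a range from 1400 nM to 6000 nM.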

Compound 4, concentration for 50% growth inhibition: 2700 nM
Beside the measured number, compound 4's estimate is 1.1-fold (0.03 log units) above it; the measured number falls inside the stated range.
By their numbers in this assay, from the lowest: compounds 1, 4, 2 and 3 (each within the scatter of the next).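

The trifluoromethyl group, with four heavy atoms in place of the single chlorine, adds a substituent change on the aromatic carbon itself to the earlier exchanges of whole aryl groups, and in this assay it gives a 1.1-fold lower number from compound 2 to compound 4 (0.03 log units; within the scatter). The other two comparisons agree, with a 1.3-fold lower number from compound 3 to compound 4 (0.12 log units; within the scatter) and no change at the digits printed from compound 1 to compound 4 (within the scatter), so all four aryl groups shown on this saturated chain carbon lie within the scatter of one another. Nothing shown gives a reason for this flat response.

Still open, going by these compounds, is whether the numbers stay this close with a carboxylic acid or an amine on that aromatic carbon in place of chloro or trifluoromethyl. The compounds shown also leave open whether a longer chain between the sulfonamide and the amine nitrogen would move the number beyond the scatter.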